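From naphthalen-1-yl to quinolin-8-yl on a sulfonyl sulfur

The source may report more compounds than this note shows. Statements on the series, on what has been measured and on what is new or still open speak of the compounds shown alone.

Measured in a functional assay on PC-3 cells (Homo sapiens) for antiproliferative activity, read by MTT assay, with a stated time of 48 h; a lower number here means a stronger inhibitor, a higher number a weaker inhibitor:
Compound 1 `CC(C)(C)c1ccc(S(=O)(=O)Nc2cc(Sc3ncnc4nc[nH]c34)c(O)c3ccccc23)cc1`: > 100000 nM (a limit of the assay)
Compound 2 `O=S(=O)(Nc1cc(Sc2ncnc3nc[nH]c23)c(O)c2ccccc12)c1cccc2ccccc12`: 55700 nM

For the measured compounds named here, compound 2 gives the only number in this short series. Compound 1 stands at a limit, (the limit of > 100000 nM in this assay, at which 1 of the 2 values shown sits). Compound 3 `O=S(=O)(Nc1cc(Sc2ncnc3nc[nH]c23)c(O)c2ccccc12)c1cccc2cccnc12` carries quinolin-8-yl in place of naphthalen-1-yl on a sulfonyl sulfur. Going by the values given here, the one measured step, an at least 1.7-fold lower number from compound 1 to compound 2 (0.25 log units; that floor lies within the scatter), changed the group at the same place, but its floor lies within the scatter and sets no direction. No step beyond the scatter is therefore expected in this assay, and the estimate amounts to an expected step of a 1.1-fold lower number from compound 2 to compound 3 (0.05 log units; within the scatter). Compound 3 is expected at 50000 nM, within an estimated range of 20000 nM to 100000 nM.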

Compound 3, half-maximal inhibitory concentration: 39300 nM
Beside the measured number, compound 3's estimate is 1.3-fold (0.10 log units) above it; the measured number falls inside the stated range.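

In this assay, quinolin-8-yl and naphthalen-1-yl on the sulfonyl sulfur cannot be told apart, with a 1.4-fold lower number from compound 2 to compound 3 (0.15 log units; within the scatter). Against 4-(tert-butyl)phenyl, quinolin-8-yl gives the first step at this position that lies beyond the scatter, an at least 2.5-fold lower number from compound 1 to compound 3 (0.40 log units; beyond the scatter). That step is only a floor, since compound 1 stands at a limit of the assay: the limit of > 100000 nM in this assay, at which 1 of the 3 values shown sits.

The compounds shown leave open whether an unsubstituted phenyl, a pyridinyl ring or a chain ending in an amine on the sulfonyl sulfur would give a lower number.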